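A few compounds are considered here, and "the series" means these few. Any claim that something is new, unique, unknown or untested is made for them only; others in the source may bear on it.

Working notes on the series. In a functional assay on M21 cells (Homo sapiens) for inhibition, read by sulforhodamine B assay, with a stated time of 48 h (on this read-out lower numbers stand for stronger inhibition of growth and higher numbers for weaker inhibition of growth), compound 2 (`c1ccc(COc2ccc(NC3=NCCO3)cc2)cc1`) gives 15900 nM and shows the weakest inhibition of growth of the three measured compounds, beyond the scatter from both others. Compound 1 (`c1ccc2cc(NC3=NCCO3)ccc2c1`) gives a lower number (3500 nM), and compound 3 (`O=C(CCl)NC(=O)Nc1ccc2c(c1)CCC2`) also gives a lower number (1700 nM).

Compound 4 (`O=C(CCl)NC(=O)Nc1ccc(OCc2ccccc2)cc1`) has not been measured. It differs from compound 2 on a nitrogen on an aromatic ring, where the one five-membered non-aromatic ring with 2 hetero atoms leaves and ((chloromethyl)carbonyl)carbamoyl enters (a group of 7 heavy atoms (3 carbon, 1 nitrogen, 2 oxygen, 1 chlorine; no ring) in place of a group of 5 heavy atoms (3 carbon, 1 nitrogen, 1 oxygen; one five-membered non-aromatic ring with 2 hetero atoms), on a nitrogen on an aromatic ring).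

Among the compounds with values here, no measured pair isolates this change, so the expectation rests on indirect evidence. Within the data shown here, the entering group is present in only one measured compound, compound 3 (1700 nM), whose core is not that of compound 2. Compound 1 and compound 2 both carry the leaving group yet differ beyond the scatter, so the core alone can shift the number and the range has to stay wide.

An estimated change a 5.7-fold lower number from compound 2 to compound 4 (0.75 log units; beyond the scatter) is expected toward stronger inhibition of growth, beyond the scatter. For compound 4 the expected value is 2800 nM, with an estimated range from 900 nM to 9000 nM.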

Compound 4, concentration for 50% growth inhibition: 5100 nM
Compound 4: middle estimate off by 1.8-fold (0.26 log units), on the low side; measured number inside the range.
By their numbers in this assay, from the lowest: compound 3; then compounds 1 and 4 (each within the scatter of the next); then compound 2.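

In this assay, within the data shown here, the change on a nitrogen on an aromatic ring gives a 3.1-fold lower number from compound 2 to compound 4 (0.49 log units; beyond the scatter), a modest step toward stronger inhibition of growth and the first direct reading of this change. With the rest of compound 4 held the same as in compound 2, ((chloromethyl)carbonyl)carbamoyl in place of the five-membered non-aromatic ring with 2 hetero atoms is enough to move the number beyond the scatter, whereas before the entering group stood only on the different core of compound 3. No supporting data on the compounds bear on what lies behind this step.

From the compounds shown here alone, the reading rests on this single pair, so it remains open whether the change gives a step of similar size and direction on the core of compound 1 or the core of compound 3. Going by these compounds, it also remains open which part of the entering group carries the step, a question that a methyl in place of the chloromethyl, or a free amine on the same nitrogen, would help to settle.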